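Lengthening the chain of compound 2 to hexyl

The source may hold more compounds than are shown below. What is called first, only, known or untested is meant among the compounds shown, and "the series" means these compounds.

In a functional assay on MCF7 cells (Homo sapiens) for inhibition, read by MTT assay, with stated times of 18 h and 4 h (a higher number here means a weaker inhibitor, a lower number a stronger inhibitor), compound 2 `CCCOP(=O)(O)OCCSC(=S)N1CCCCC1` gives > 100000 nM and that entry is a limit of the assay, not a number. Compound 1 `CCCCCCCCCCCCCCCCOP(=O)(O)OCCSC(=S)N1CCCCCC1` reads > 100000 nM and this too is a limit. Compound 3 `CCCOP(=O)(O)OCCSC(=S)N1CCCC1` does give a number, 73000 nM in the same test. Compound 2 therefore stands at the limit of > 100000 nM in this assay, at which 2 of the 3 values shown sit, and the starting point for any comparison is a limit.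

Compound 4 `CCCCCCOP(=O)(O)OCCSC(=S)N1CCCCC1` differs from compound 2 in one place. The change is propyl in place of hydrogen on a saturated chain carbon, three bonds along the chain from an oxygen on an unsaturated carbon and, seen further out along the chain, it turns propyl to hexyl.

Going by the values given here, the only measured step is an at least 1.3-fold lower number from compound 2 to compound 3 (0.13 log units; that floor lies within the scatter) and it concerns the group on a thiocarbonyl carbon, not this chain. Among the compounds with values here, no measured step changes the chain alone. Compound 1 differs from compound 2 in more than one place, and their two values show only the same limit. Compound 2, with its limit of > 100000 nM in this assay as the anchor, gives no sign of a large shift.

No step beyond the scatter is expected, and the estimated size is a number no higher from compound 2 to compound 4 (the limit leaves the size open) for this change. Compound 4 is expected near 100000 nM with an estimated range from 40000 nM to 250000 nM and it may well return only a limit.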

Compound 4, half-maximal inhibitory concentration: 62000 nM
For compound 4 the middle estimate is 1.6-fold (0.21 log units) above the measured one, and the stated range covers the measured number.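

In this assay, the hexyl chain of compound 4 yields a measured number, so this position on the chain can tolerate the extension from propyl to hexyl without the reading being lost at the assay limit. Going by these compounds alone, the step, an at least 1.6-fold lower number from compound 2 to compound 4 (0.20 log units; that floor lies within the scatter), is the first one that concerns this chain alone, whereas the earlier step concerned the group on the thiocarbonyl carbon. Even so, it gives only a floor for the change and cannot show how large the real difference is, and the comparison rests on a starting point that is not a number: the limit of > 100000 nM in this assay, at which 2 of the 4 values shown sit.

As far as these compounds go, whether a butyl or pentyl chain, a longer chain such as octyl, or a chain ending in an amine or a carboxylic acid would move the number clearly beyond the scatter remains open. Compound 1 does not settle the question of longer chains: it differs from compound 2 in more than one place, and for compound 1 the entry of > 100000 nM is a limit.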